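The compounds below may be only part of what the source reports. "The series", "measured", "known", "first", "only" and "open" are said of these compounds alone.

Series notes. Of the compounds shown here, two of the shared core have been measured in a functional assay on the whole organism (strain Wistar albino) for inhibition, with Rattus norvegicus as the target, read by paw edema, with a stated time of 2 h, at a dose of 25 mg/kg by the oral route; on this read-out higher numbers stand for more inhibition at the one dose given (going by the name of the read-out) and lower numbers for less inhibition. Compound 1, `CSc1nn(-c2ccc(S(N)(=O)=O)cc2)c2nc(Nc3ccccc3)n(-c3ccccc3)c(=O)c12`, gives 54.1% in this assay. Compound 2, `O=c1c2c(Nc3ccc([N+](=O)[O-])cc3)nn(-c3ccccc3)c2nc(Nc2ccccc2)n1-c1ccccc1`, gives 29% in this assay; this is the lower of the two numbers, and the gap to compound 1 lies beyond the usual scatter. Going by the values given here, compound 1 and compound 2 differ in more than one place, so their two values show only that compound 1 sits higher; they do not separate the contributions of the single changes.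

Compound 3, `NS(=O)(=O)c1ccc(-n2nc(Nc3ccc([N+](=O)[O-])cc3)c3c(=O)n(-c4ccccc4)c(Nc4ccccc4)nc32)cc1`, has not been measured. It differs from compound 2 as follows: sulfamoyl in place of hydrogen on an aromatic carbon. Cut one bond further out, the change reads phenyl to 4-sulfamoylphenyl. Among the compounds with values here, compound 1 also carries a 4-sulfamoylphenyl, but it differs from compound 3 elsewhere, so no measured step gives the size of this change in this assay. The expected step of a number 11 percentage points higher from compound 2 to compound 3 (beyond the scatter) is moderate and upward, because compound 1 gives 54.1% while carrying the same group. Compound 3 is estimated at 40%, with a range from 28% to 52%.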

Compound 3, a percentage reported as inhibition, in the whole organism at one dose (the size of the read-out at that dose, not a potency): 55.3%
Beside the measured number, compound 3's estimate is 15.3 percentage points below it; the whole stated range lies below it.
By their numbers in this assay, from the lowest: compound 2; then compounds 1 and 3 (each within the scatter of the next).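

Working notes. In this assay, going by these compounds alone, the change from phenyl to 4-sulfamoylphenyl now has a measured size of a number 26.3 percentage points higher from compound 2 to compound 3 (beyond the scatter) with the (4-nitrophenyl)amino group held constant, the first single-change reading at this position. With 4-sulfamoylphenyl held constant, (4-nitrophenyl)amino in place of methylsulfanyl on an aromatic carbon gives a number 1.2 percentage points higher from compound 1 to compound 3 (within the scatter) and so leaves this read-out unresolved between those two groups at the one dose given. No measurement in hand accounts for the size of either step.

On these data alone, the sulfamoyl step rests on a single pair, so it remains open whether the same change gives a step of similar size when methylsulfanyl replaces (4-nitrophenyl)amino on the shared core. As far as these compounds go, it also remains open how a carboxylic acid or a methylsulfonyl group would read in place of sulfamoyl on that six-membered aromatic ring, and how an amine or a longer chain would read in place of (4-nitrophenyl)amino.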